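A few compounds are considered here, and "the series" means these few. Any claim that something is new, unique, unknown or untested is made for them only; others in the source may bear on it.

Measured compounds:
Compound 1, `Nc1nc(N)c2c(-c3ccsc3)cn([C@@H]3O[C@H](CO)[C@@H](O)[C@H]3O)c2n1` — in a functional assay on CEM-DNR-bulk cells (Homo sapiens), read by MTT assay, with a stated time of 72 h (a lower number here means a stronger inhibitor, a higher number a weaker inhibitor), compound 1 gives > 20000 nM, a limit of the assay.
Compound 2, `COc1nc(N)nc2c1c(-c1ccccc1)cn2[C@@H]1O[C@H](CO)[C@@H](O)[C@H]1O` — in this assay compound 2 gives > 20000 nM, a limit of the assay.
Compound 3, `Cc1nc(N)c2c(-c3ccccc3)cn([C@@H]3O[C@H](CO)[C@@H](O)[C@H]3O)c2n1` — in this assay compound 3 gives > 20000 nM, a limit of the assay.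

Going by the values given here, compound 3 therefore stands at the limit of this assay, and so do the two other measured compounds; no compound has a number, so no step among them can be sized, and none can be called stronger or weaker than another. The next compound is compound 4, `Nc1nc(N)c2c(-c3ccccc3)cn([C@@H]3O[C@H](CO)[C@@H](O)[C@H]3O)c2n1`. It differs from compound 3 by amino in place of methyl on an aromatic carbon, an amino entering where a methyl leaves, on an aromatic carbon between two ring nitrogen atoms. Compound 1 carries the same amino group on a core that is otherwise close to that of compound 4 and also sits at the limit (the limit of > 20000 nM in this assay, at which 3 of the 3 values shown sit). On this footing the step expected is a number no higher from compound 3 to compound 4 (the limit leaves the size open), none beyond the scatter, with a limit the most likely outcome. Compound 4 is estimated at 20000 nM, in a range from 8000 nM to 40000 nM.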

Compound 4, half-maximal inhibitory concentration: > 20000 nM
Compound 4: only a limit was reported; the forecaster's own chance of this, stated with the estimate: 85%; the middle value lies on the limit itself.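

Compound 4 joins compounds 1, 2 and 3 at the limit of this assay, so none of its steps from those three compounds can be read: the limit of > 20000 nM in this assay, at which 4 of the 4 values shown sit.

The compounds shown leave open which change to the shared core, if any, would bring a measurable value in this assay.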